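The source may hold more compounds than are shown below. What is called first, only, known or untested is meant among the compounds shown, and "the series" means these compounds.

Measured compounds, cytotoxicity in a functional assay on NCI-H460 cells (Homo sapiens) for cytotoxicity, read by MTT assay, with a stated time of 72 h; on this read-out lower numbers stand for stronger inhibition and higher numbers for weaker inhibition:

compound 1 `CN(C)CCCNc1nc(-c2ccc(NC(=O)Nc3ccccc3F)cc2)nc2ccsc12` gives 530 nM
compound 2 `CN(C)CCNc1nc(-c2ccc(NC(=O)Nc3ccc(Cl)cc3)cc2)nc2c(Cl)c(Cl)sc12` gives 300 nM
compound 3 `CCN(CC)CCCNc1nc(-c2ccc(NC(=O)Nc3ccccc3)cc2)nc2c(Cl)c(Cl)sc12` gives 850 nM

Compound 3 carries the highest of the three numbers in this assay. Its gap to compound 1 falls within the scatter of repeated measurements, so no order between those two can be read; its gap to compound 2 lies beyond the scatter, and compound 2 therefore shows the lower number of that pair. Compound 2 differs from compound 3 in more than one place, so its value says nothing specific about any single change.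

Compound 4 `CCN(CC)CCCNc1nc(-c2ccc(NC(=O)Nc3ccc(Cl)cc3)cc2)nc2c(Cl)c(Cl)sc12` is not yet measured. It differs from compound 3 by chloro in place of hydrogen on an aromatic carbon, on the phenyl of the urea, para to a large group. Among the compounds with values here, no step between measured compounds isolates this change. The expectation for the step from compound 3 to compound 4 in this assay is a modest move toward a lower number, a 1.9-fold lower number from compound 3 to compound 4 (0.28 log units; within the scatter), at the edge of the scatter rather than clearly beyond it. For compound 4 the estimated value is 450 nM, with a range from 150 nM to 1400 nM.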

Compound 4, half-maximal inhibitory concentration: 270 nM
For compound 4 the middle estimate is 1.7-fold (0.22 log units) above the measured one, within the range that was stated.
By their numbers in this assay, from the lowest: compounds 4, 2, 1 and 3 (each within the scatter of the next, the first and the last beyond it).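

In this assay, within the data shown here, the step from hydrogen to chloro gives the only single-change reading on the phenyl of the urea: phenylcarbamoyl to (4-chlorophenyl)carbamoyl brings a 3.1-fold lower number from compound 3 to compound 4 (0.50 log units; beyond the scatter) and so separates this pair beyond the scatter. With the 4-chlorophenyl group held in place, (diethylamino)methyl in place of dimethylamino on the saturated chain brings a 1.1-fold lower number from compound 2 to compound 4 (0.05 log units; within the scatter) and no order can be read for that change. Nothing at hand bears on the cause of either step.

Whether the chloro step depends on this group remains open, since fluoro, methoxy or trifluoromethyl at the same place are not among the compounds shown. Also open, as far as these compounds go, is whether it carries over to the core of compound 1, or to a side chain ending in a morpholine or piperidine.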